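Swapping phenyl for a protected amino chain

A few compounds are considered here, and "the series" means these few. Any claim that something is new, unique, unknown or untested is made for them only; others in the source may bear on it.

Measured in a functional assay on ID8 cells (Mus musculus) for antiproliferative activity (a higher number here means a weaker inhibitor, a lower number a stronger inhibitor), so far:
compound 1 `O=C(Nc1ccc(O)c2c(=O)cc(-c3ccccc3Cl)oc12)c1ccccc1` gives 13000 nM
compound 2 `O=C(Nc1c(O)cc(O)c2c(=O)cc(-c3ccccc3Cl)oc12)c1ccccc1` gives "not determined" (no result reported)

Going by the values given here, compound 1 holds the only number here, so it cannot yet be ranked against any other compound. Compound 2 has no result to compare.

Compound 3 `C[C@H](NC(=O)OC(C)(C)C)C(=O)Nc1ccc(O)c2c(=O)cc(-c3ccccc3Cl)oc12` keeps the core of compound 1 and alters one group, with 1-((tert-butoxycarbonyl)amino)ethyl in place of phenyl on a carbonyl carbon. Among the compounds with values here, no measured pair shows what such a swap does in this assay, so neither direction can be favoured, and no step beyond the usual scatter is expected. The estimated step is a 1.1-fold lower number from compound 1 to compound 3 (0.03 log units; within the scatter), although the uncertainty is wide with a single number as the only anchor. Compound 3 is estimated at 12000 nM (expected range 3500 nM to 40000 nM).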

Compound 3, half-maximal inhibitory concentration: 9800 nM
The estimate for compound 3 lay 1.2-fold (0.09 log units) above the measured number; low and high end bracket the measured number.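

In this assay, putting 1-((tert-butoxycarbonyl)amino)ethyl in place of phenyl on a carbonyl carbon gives a 1.3-fold lower number from compound 1 to compound 3 (0.12 log units; within the scatter). This first pair shows that a large swap at this position, from an aromatic ring to a ringless chain carrying a hydrogen-bond donor, hydrogen-bond acceptors and a defined stereocentre, leaves the number level with that of the phenyl compound. Nothing measured here accounts for this outcome.

Going by these compounds alone, with only one swap at this position, it remains open whether any part of the new chain matters for the read-out. A free amine in place of the protected amino group, a longer chain or a carboxylic acid on this carbonyl carbon could still show whether the position responds to change at all.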